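Acetoxymethyl for a ring methyl on a quinolinone scaffold

The compounds below may be only part of what the source reports. "The series", "measured", "known", "first", "only" and "open" are said of these compounds alone.

Measured compounds:
compound 1 `Cc1ccc(-c2c(O)nc3cc(Cl)c([N+](=O)[O-])cc3c2OCCC2CCCCN2)c(C)c1` — 400 nM
compound 2 `O=C(Nc1cc2c(OCCC3CCCCN3)c(-c3ccc(Cl)c(Cl)c3)c(O)nc2cc1Cl)NC1CC1` — 18 nM

The series was characterised in a functional assay on cells (Pituitary gland cell) for antagonist activity at Gonadotropin-releasing hormone receptor (Rattus norvegicus); on this read-out higher numbers stand for weaker inhibition and lower numbers for stronger inhibition. Compound 1 gives 400 nM and holds the higher of the two measured numbers. Compound 2 gives 18 nM in this assay, and the gap between compound 2 and compound 1 lies beyond the scatter of repeated measurements. Compound 2 differs from compound 1 in more than one place, so its lower number cannot be attributed to any single change.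

The unmeasured compound 3 `CC(=O)OCc1cc(C)cc(-c2c(O)nc3cc(Cl)c([N+](=O)[O-])cc3c2OCCC2CCCCN2)c1` keeps the core of compound 1 and alters only the aryl substituent: 3-(acetoxymethyl)-5-methylphenyl in place of 2,4-dimethylphenyl on an aromatic carbon. The 2-(piperidin-2-yl)ethoxy group, the hydroxy group, the chloro and the nitro group are all retained. For the measured compounds named here, no measured pair in the set isolates this exchange of aryl groups, so there is no directly comparable step to draw on.

On that basis compound 3 is expected to give 300 nM in this assay, within a range of 70 nM to 1300 nM, which corresponds to an estimated step of a 1.3-fold lower number from compound 1 to compound 3 (0.12 log units; within the scatter) — no change beyond the scatter is predicted.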

Compound 3, half-maximal inhibitory concentration: 45 nM
The estimate for compound 3 lay 6.7-fold (0.82 log units) above the measured number; the measured number lies below the stated range.
By their numbers in this assay, from the lowest: compound 2; then compound 3; then compound 1.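

In this assay, the aryl group on the aromatic carbon ortho to the 2-(piperidin-2-yl)ethoxy group and ortho to the hydroxy group proves able to shift the read-out on its own: the exchange of 2,4-dimethylphenyl for 3-(acetoxymethyl)-5-methylphenyl gives an 8.9-fold lower number from compound 1 to compound 3 (0.95 log units; beyond the scatter) while everything else in the core of compound 1 stays as it was. The position therefore takes a larger group, with 12 heavy atoms in place of 8 and 2 hydrogen-bond acceptors in place of 0, and inhibition grows stronger rather than weaker in this one pair. Nothing available here accounts for the size of this step.

The exchange alters two things at once, the acetoxymethyl group and the placement of the methyl on the ring, and a 3,5-dimethylphenyl group would be needed to separate them. On these data alone, it also remains open whether the ester itself matters, which a hydroxymethyl or a methoxymethyl group in place of acetoxymethyl would test.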